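The compounds below may be only part of what the source reports. "The series", "measured", "known", "first", "only" and "open" are said of these compounds alone.

Measured compounds:
compound 1 `CCNc1ccc2c(c1)OC(N)=C(C#N)C2c1cc(Br)c(OC)c(OC)c1` gives 14000000 nM
compound 2 `COc1cc(C2C(C#N)=C(N)Oc3c2ccc(O)c3N)cc(Br)c1OC` gives 61000000 nM
compound 3 `COc1cc(C2C(C#N)=C(N)Oc3cc(O)ccc32)cc(Br)c1OC` gives 130000000 nM

All three values come from a functional assay on T47D cells (Homo sapiens) for activation; a higher number here means that more compound is needed for the effect, a lower number that less compound is needed. Compound 3 stands with the highest number of the three in this assay: compound 2 lies nearest, at a 2.1-fold higher number from compound 2 to compound 3 (0.33 log units; beyond the scatter), and compound 1 lies furthest, at a 9.3-fold higher number from compound 1 to compound 3 (0.97 log units; beyond the scatter), so compound 3 needs the most material of the set.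

Compound 4 `COc1cc(C2C(C#N)=C(N)Oc3cc(Cl)ccc32)cc(Br)c1OC` has not yet been measured. It differs from compound 3 in one place: chloro in place of hydroxy on an aromatic carbon. The change sits on an aromatic carbon of a six-membered aromatic ring of carbon only, part of a fused system of two rings.

Going by the values given here, no measured step exchanges hydroxy for chloro, so none bears on it directly. The step from compound 1 to compound 3, a 9.3-fold higher number from compound 1 to compound 3 (0.97 log units; beyond the scatter), shows that the group at this carbon matters, and that hydroxy gives a higher number than ethylamino. The step from compound 2 to compound 3, a 2.1-fold higher number from compound 2 to compound 3 (0.33 log units; beyond the scatter), concerns a different carbon and gives no guidance here. Whether chloro lands nearer to the ethylamino or to the hydroxy result cannot be read from these compounds.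

The author therefore expects compound 4 to change by a 1.6-fold lower number from compound 3 to compound 4 (0.21 log units; within the scatter) in this assay, a modest step with the direction uncertain, and estimates compound 4 at 80000000 nM, between 20000000 nM and 300000000 nM.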

Compound 4, half-maximal effective concentration: 160000000 nM
Beside the measured number, compound 4's estimate is 2.0-fold (0.30 log units) below it; measured number inside the range.
By their numbers in this assay, from the lowest: compound 1; then compound 2; then compounds 3 and 4 (each within the scatter of the next).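

In this assay, the exchange of hydroxy for chloro on this aromatic carbon removes one hydrogen-bond donor and one hydrogen-bond acceptor by count, yet the result is a 1.2-fold higher number from compound 3 to compound 4 (0.09 log units; within the scatter), so the two groups cannot be told apart here and the donor and acceptor counted on hydroxy show no measurable link to the number at this position. The contrast with ethylamino now rests on two groups rather than one, since chloro in place of ethylamino gives an 11-fold higher number from compound 1 to compound 4 (1.06 log units; beyond the scatter), which leaves ethylamino as the only group at this carbon with a clearly lower number among the compounds shown. Nothing measured here explains why hydroxy and chloro read alike or why ethylamino stands apart.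

Going by these compounds, it remains open whether the lower number of compound 1 goes with the nitrogen attached to the aromatic carbon or with its ethyl chain, a question that a plain amino group or a longer chain such as propylamino at this carbon would address. It is also unknown how a methoxy group or a bare hydrogen at this carbon would compare with hydroxy and chloro.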